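Cyano for formyl on a pyrrole-type core: expected potency

This account rests on a few compounds, and the source may have more. Where it says the series, first, only, none or still open, it means among the compounds named here.

Compound 1 `Cc1c(C=O)cc(-c2ccc(S(C)(=O)=O)cc2)n1-c1ccc(F)c(F)c1`: in an assay on J774 cells for inhibition of prostaglandin G/H synthase 1 (Mus musculus), read by immunoassay, with stated times of 15 min and 30 min (on this read-out higher numbers stand for weaker inhibition and lower numbers for stronger inhibition), compound 1 gives > 10000 nM, which is a limit of the assay.
Compound 2 `Cc1c(C=O)cc(-c2ccc(S(C)(=O)=O)cc2)n1-c1ccccc1`: in this assay compound 2 gives > 10000 nM, also a limit.
Compound 3 `Cc1c(/C=N\O)cc(-c2ccc(S(C)(=O)=O)cc2)n1-c1ccc(F)c(F)c1`: in this assay compound 3 gives > 10000 nM, also a limit.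

Compound 2 therefore stands at the limit, and so do the other two, as the limit of > 10000 nM in this assay, at which 3 of the 3 values shown sit, shows. Compound 4 `Cc1c(C#N)cc(-c2ccc(S(C)(=O)=O)cc2)n1-c1ccccc1` differs from compound 2 in one place: cyano in place of formyl on an aromatic carbon. Among the measured compounds shown here, two measured steps touch this series, a step that the two limits leave unreadable from compound 1 to compound 2 and a step that the two limits leave unreadable from compound 1 to compound 3, but both run between limits, so neither size nor direction can be read from them. No readable step exists for exchanging one small carbon group for another on this ring. The value of compound 4 in this assay is expected to stay near the limit, estimated at 20000 nM with a range from 5000 nM to 100000 nM. The step from compound 2 to compound 4 is thus expected to be a step that the limit leaves unreadable from compound 2 to compound 4, which is no step beyond the scatter.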

Compound 4, half-maximal inhibitory concentration: > 10000 nM
Compound 4: only a limit was reported; the forecaster's own chance of this, stated with the estimate: 80%; the middle value lies beyond the limit too.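

No step can be read from compound 2 to compound 4, because both values are limits: the limit of > 10000 nM in this assay, at which 4 of the 4 values shown sit.
In this assay the compounds shown leave open how strongly any of them inhibits, and whether cyano or formyl makes any difference.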